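A few compounds are considered here, and "the series" means these few. Any claim that something is new, unique, unknown or untested is made for them only; others in the source may bear on it.

Series notes. Compound 1 `CCOC(=O)C1=Cc2ccccc2OC1(OCc1cn(CC(=O)Nc2ccccc2F)nn1)C(F)(F)F` is the reference point of the set. Among the measured compounds shown here, in a functional assay on HeLa cells (Homo sapiens) for inhibition, read by MTT assay, with a stated time of 24 h (on this read-out lower numbers stand for stronger inhibition and higher numbers for weaker inhibition), compound 1 gives 49900 nM, the only numerical value measured so far. Compound 2 `O=C(O)C1=Cc2ccccc2OC1(OCc1cc(-c2ccc(F)cc2F)no1)C(F)(F)F` was run in the same test and returned no number. In this assay compound 2 gives > 150000 nM, which is a limit of the assay rather than a measured value. For the measured compounds named here, the whole record thus consists of one number and one limit (the limit of > 150000 nM in this assay, at which 1 of the 2 values shown sits); no step between two measured compounds exists, so the size of change produced by any single alteration is not yet calibrated.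

Compound 3 `CCOC(=O)C1=Cc2ccccc2OC1(OCc1cn(CC(=O)Nc2cccc(Cl)c2)nn1)C(F)(F)F` is the next compound to be measured. It differs from compound 1 in one place: 3-chlorophenyl in place of 2-fluorophenyl on an amide-type nitrogen. Cut one bond further out, the change reads (2-fluorophenyl)carbamoyl to (3-chlorophenyl)carbamoyl; the rest of the shared core is unchanged. Without a measured step to lean on, the expected step of a 1.1-fold lower number from compound 1 to compound 3 (0.04 log units; within the scatter) is taken to lie within the scatter of repeats, in no firm direction. On that basis compound 3 is estimated at 45000 nM, with a range from 18000 nM to 120000 nM.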

Compound 3, half-maximal inhibitory concentration: 12300 nM
The estimate for compound 3 lay 3.7-fold (0.56 log units) above the measured number; measured number outside the range, below it.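

In this assay, 3-chlorophenyl in place of 2-fluorophenyl on the amide-type nitrogen gives a 4.1-fold lower number from compound 1 to compound 3 (0.61 log units; beyond the scatter), so this position is the first in the series shown to move the read-out, and the series now has one calibrated step for a single alteration. The groups that leave and enter have the same counts of heavy atoms, hydrogen-bond donors and hydrogen-bond acceptors, yet fluorine gives way to chlorine and the 2-substituted phenyl to a 3-substituted one in the same step, so this single comparison cannot divide the step between those two differences. No measurement shown accounts for the size or direction of the step.

The compounds shown leave open how 3-fluorophenyl and 2-chlorophenyl would compare, either of which would separate the identity of the halogen from its place in the group name, and how unsubstituted phenyl would stand against both. Also open, from the compounds shown here alone, is whether the same step would hold with a carboxylic acid in place of the ethyl ester on the shared core.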